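Adding a Second Chloro to the Aryl Ring of Compound 3

The compounds below may be only part of what the source reports. "The series", "measured", "known", "first", "only" and "open" are said of these compounds alone.

In a functional assay on EKVX cells (Homo sapiens) for inhibition, read by sulforhodamine B assay, with a stated time of 48 h (on this read-out lower numbers stand for stronger inhibition of growth and higher numbers for weaker inhibition of growth), three compounds have been measured. Among the compounds with values here, compound 1 `N#C/C(=C\N1CCN(C(=O)c2ccco2)C1=S)C(=O)Nc1ccc(Cl)cc1` gives 10 nM, while compound 2 `N#C/C(=C\N1CCN(C(=O)c2ccco2)C1=S)C(=O)c1ccccc1` gives 17800 nM; the step of a 1800-fold higher number from compound 1 to compound 2 (3.25 log units; beyond the scatter) is the only single-change comparison among them. Compound 3 `O=CN1CCN(c2ccc(Cl)cc2)C1=S` gives 15500 nM, a number of the same size as that of compound 2, within the scatter, and far higher than that of compound 1, beyond the scatter.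

Compound 4 `O=CN1CCN(c2ccc(Cl)c(Cl)c2)C1=S` differs from compound 3 by chloro in place of hydrogen on an aromatic carbon, the new group sitting on an aromatic carbon of a six-membered aromatic ring of carbon only, ortho to a chloro group and meta to a group of 8 heavy atoms. Within the data shown here, no measured step involves the addition of a chloro group; the step from compound 1 to compound 2 concerns a different part of the shared core and does not bear on this change. The step of a 1.3-fold lower number from compound 3 to compound 4 (0.11 log units; within the scatter) is therefore expected to stay within the scatter. Compound 4 is estimated to give 12000 nM, between 4000 nM and 40000 nM.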

Compound 4, concentration for 50% growth inhibition: 17500 nM
For compound 4 the middle estimate is 1.5-fold (0.16 log units) below the measured one; low and high end bracket the measured number.
By their numbers in this assay, from the lowest: compound 1; then compounds 3, 4 and 2 (each within the scatter of the next).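

In this assay, within the data shown here, the change to compound 4 comes to a 1.1-fold higher number from compound 3 to compound 4 (0.05 log units; within the scatter) and is the first measured step on the aryl ring of compound 3. It shows that chloro in place of hydrogen on this aromatic carbon, ortho to a chloro group and meta to a group of 8 heavy atoms, leaves the number unchanged within the scatter. No measured evidence is available that would explain this result.

Whether this aromatic carbon is equally insensitive to other groups remains open, as neither an amine, a methoxy group nor a carboxylic acid in place of the hydrogen appears among the compounds shown. On these data alone, it is also open whether the same added chloro would leave the number unchanged on the aryl ring of compound 1, whose shared core differs from that of compound 3.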